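Swapping a side chain in a series held at a limit

The source may report more compounds than this note shows. Statements on the series, on what has been measured and on what is new or still open speak of the compounds shown alone.

Measured so far in a functional assay on HCT-116 cells (Homo sapiens) for antiproliferative activity, read by sulforhodamine B assay, with a stated time of 72 h; a lower number here means a stronger inhibitor, a higher number a weaker inhibitor:

Compound 1 `Cn1cc(-c2ccc(=O)n(CCOc3ccnc4cc(OCCCCCC(=O)NO)ccc34)n2)cn1` gives > 10000 nM as a limit
Compound 2 `Cn1cc(-c2ccc(=O)n(CCOc3ccnc4cc(OCCCCCCC(=O)NO)ccc34)n2)cn1` gives > 10000 nM as a limit
Compound 3 `CNC(=O)CCCCCOc1ccc2c(OCCn3nc(-c4cnn(C)c4)ccc3=O)ccnc2c1` gives > 10000 nM as a limit

Compound 3 stands at > 10000 nM in this assay and this is a limit, not a number. Every measured compound shares one reading, namely the limit of > 10000 nM in this assay, at which 3 of the 3 values shown sit, and that is the whole of the evidence.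

Compound 4 `Cn1cc(-c2ccc(=O)n(CCOc3ccnc4cc(C(=O)Nc5ccccc5N)ccc34)n2)cn1` carries (2-aminophenyl)carbamoyl in place of (5-(methylcarbamoyl)pentyl)oxy on an aromatic carbon of the shared core (2-aminophenyl)carbamoyl in place of (5-(methylcarbamoyl)pentyl)oxy on an aromatic carbon and the chain is gone. Going by the values given here, no measured compound carries this new group.

Among the compounds with values here, three measured steps concern the end of the molecule that changes. They are a step that the two limits leave unreadable from compound 1 to compound 2 and a step that the two limits leave unreadable from compound 1 to compound 3 and a step that the two limits leave unreadable from compound 2 to compound 3 and none has a readable size. No direction follows from them.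

Compound 3 at > 10000 nM is a limit that offers the only anchor, and compound 4 is expected to stay close to it. The expected change is a step that the limit leaves unreadable from compound 3 to compound 4 and this estimate has no direction that the data support. For compound 4 the estimate is 12000 nM with an expected range from 3000 nM to 40000 nM and a report of only a limit is likely.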

Compound 4, half-maximal inhibitory concentration: > 10000 nM
Compound 4 was reported as a limit; the forecaster's own chance of this, stated with the estimate: 70%; the middle value lies beyond the limit too.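

In this assay compound 4 gives > 10000 nM, which is a limit and not a number. Going by these compounds alone, no step from compound 1, compound 2 or compound 3 to compound 4 can be read, as all share one reading: the limit of > 10000 nM in this assay, at which 4 of the 4 values shown sit. The compounds shown leave open how strongly any of them inhibits, and whether any of these side-chain changes matters in this assay.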